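Methyl to methoxy on the aniline ring of compound 1

A few compounds are considered here, and "the series" means these few. Any claim that something is new, unique, unknown or untested is made for them only; others in the source may bear on it.

Working notes on a small set of anilinopyrimidines tested in an assay on isolated protein for inhibition of phosphatidylinositol 4,5-bisphosphate 3-kinase catalytic subunit beta isoform (Homo sapiens); on this read-out higher numbers stand for weaker inhibition and lower numbers for stronger inhibition. Compound 1 `Cc1cccc(Nc2nccc(-c3ccc(Cl)cc3Cl)n2)c1` gives 851 nM in this assay; compound 3 `Clc1ccc(Nc2nccc(-c3ccc(Br)cc3)n2)cc1` gives 946 nM and compound 2 `O=[N+]([O-])c1ccc(Nc2nccc(-c3ccc(Br)cc3)n2)cc1` gives 961 nM, both within the scatter of compound 1. Among the measured compounds shown here, the only step available, a 1.0-fold lower number from compound 2 to compound 3 (0.01 log units; within the scatter), concerns a different group on the same ring and did not move the number. Compound 4 `COc1cccc(Nc2nccc(-c3ccc(Cl)cc3Cl)n2)c1` differs from compound 1 by methoxy in place of methyl on an aromatic carbon. For the measured compounds named here, no measured step covers this exchange, so nothing in the set argues for a shift beyond the scatter. The expected step of a 1.0-fold lower number from compound 1 to compound 4 (0.00 log units; within the scatter) is therefore flat, and compound 4 is estimated at 850 nM, within 400 nM to 1800 nM, in this assay.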

Compound 4, half-maximal inhibitory concentration: 893 nM
For compound 4 the middle estimate is 1.1-fold (0.02 log units) below the measured one, and the stated range covers the measured number.
By their numbers in this assay, from the lowest: compounds 1, 4, 3 and 2 (each within the scatter of the next).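

In this assay, methoxy in place of methyl on this aromatic carbon, meta to a large group, gives a 1.0-fold higher number from compound 1 to compound 4 (0.02 log units; within the scatter), so the hydrogen-bond acceptor that methoxy brings leaves the number within the scatter. Among the compounds shown here, this is the first exchange at this position in the set, and the only earlier step concerned a different group. No measurement at hand explains the flat result.

Going by these compounds, whether an amine, a carboxylic acid or a longer chain such as ethoxy on this carbon would also stay within the scatter remains open.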